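Cytotoxicity on Vero cells: from a fluorophenyl to a hydroxyphenyl

The compounds below may be only part of what the source reports. "The series", "measured", "known", "first", "only" and "open" are said of these compounds alone.

Measured so far:
compound 1 `O=C1CSC(c2cccc(F)c2)N1CCN1CCCCC1` gives 27%
compound 2 `O=C1CSC(c2c(Cl)cccc2Cl)N1CCN1CCCCC1` gives 11%
compound 3 `O=C1CSC(c2ccccc2[N+](=O)[O-])N1CCN1CCCCC1` gives 100%

In an ADME assay on Vero cells (Chlorocebus sabaeus) for cytotoxicity, read by neutral red uptake, tested at 787 ug/mL (on this read-out higher numbers stand for a weaker effect at the one concentration tested and lower numbers for a stronger effect), compound 1 stands second highest of the three numbers shown. Its nearest neighbour is compound 2, whose number lies lower by a gap beyond the scatter, and its furthest is compound 3, whose number lies higher by a gap far beyond the scatter.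

Compound 4 `O=C1CSC(c2ccc(O)cc2)N1CCN1CCCCC1` has not yet been measured. It differs from compound 1 in one place: 4-hydroxyphenyl in place of 3-fluorophenyl on a saturated ring carbon

Within the data shown here, no measured step between two compounds differing in one place is available, so the size of this change is uncertain. The step of a number 18 percentage points higher from compound 1 to compound 4 (beyond the scatter) is expected to be small to moderate and upward. Compound 4 is estimated at 45%, within a range from 15% to 90%.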

Compound 4, a percentage reported as activity, at one concentration (the size of the read-out at that concentration, not a potency): 57%
Estimate against measurement, compound 4: 12 percentage points below, within the range that was stated.
By their numbers in this assay, from the lowest: compound 2; then compound 1; then compound 4; then compound 3.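

In this assay, among these compounds, 4-hydroxyphenyl in place of 3-fluorophenyl on the saturated ring carbon gives a number 30 percentage points higher from compound 1 to compound 4 (beyond the scatter), the first step that isolates this position and shows that a change of this one group alone moves the read-out. The step changes both the substituent and its place on the phenyl ring, and it cannot apportion the shift between them. No available evidence bears on why the number rises.

Open, on these data alone, is whether 4-fluorophenyl or 3-hydroxyphenyl would separate those two changes. Also open, as far as these compounds go, is how a 4-aminophenyl or 4-carboxyphenyl group would read at this carbon.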